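Swapping the Aryl Group on the Amide Carbonyl

This account rests on a few compounds, and the source may have more. Where it says the series, first, only, none or still open, it means among the compounds named here.

Of the compounds shown here, three sharing one core have been measured in a functional assay on KB cells (Homo sapiens) for antiproliferative activity, read by MTT assay, with a stated time of 72 h; on this read-out higher numbers stand for weaker inhibition and lower numbers for stronger inhibition. Compound 1 `CC(=O)N(C)c1ccc2[nH]c(-c3n[nH]c4ccccc34)cc2n1` gives 10300 nM, compound 2 `CN(C(=O)c1ccc(Cl)cc1)c1ccc2[nH]c(-c3n[nH]c4ccccc34)cc2n1` gives 630 nM, and compound 3 `COc1cccc(C(=O)N(C)c2ccc3[nH]c(-c4n[nH]c5ccccc45)cc3n2)c1` gives 9010 nM. Compound 3 therefore stands second highest of the three, close to compound 1 and far from compound 2, as the step of a 14-fold higher number from compound 2 to compound 3 (1.16 log units; beyond the scatter) shows. From the compounds shown here alone, compound 4 `CN(C(=O)c1ccc([N+](=O)[O-])cc1)c1ccc2[nH]c(-c3n[nH]c4ccccc34)cc2n1` is still untested; its change from compound 3 is 4-nitrophenyl in place of 3-methoxyphenyl on a carbonyl carbon. The steps of a 16-fold lower number from compound 1 to compound 2 (1.21 log units; beyond the scatter) and a 14-fold higher number from compound 2 to compound 3 (1.16 log units; beyond the scatter) both show 4-chlorophenyl giving a much lower number than methyl or 3-methoxyphenyl. Compound 4 carries 4-nitrophenyl, another substituted phenyl on that carbonyl, so a sizeable drop is expected, a 6.0-fold lower number from compound 3 to compound 4 (0.78 log units; beyond the scatter), resting on a 14-fold higher number from compound 2 to compound 3 (1.16 log units; beyond the scatter) alone. Compound 4 is estimated at 1500 nM, with a range from 300 nM to 8000 nM.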

Compound 4, half-maximal inhibitory concentration: 20200 nM
Estimate against measurement, compound 4: 13-fold (1.13 log units) below, outside the stated range (above it).
By their numbers in this assay, from the lowest: compound 2; then compounds 3, 1 and 4 (each within the scatter of the next, the first and the last beyond it).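

At this carbonyl position, a substituted phenyl ring does not by itself bring a low number: nitro in place of chloro on the same ring gives a 32-fold higher number from compound 2 to compound 4 (1.51 log units; beyond the scatter), leaving compound 2 alone far below the others. Replacing 3-methoxyphenyl with 4-nitrophenyl gives a 2.2-fold higher number from compound 3 to compound 4 (0.35 log units; beyond the scatter), while replacing methyl with 4-nitrophenyl gives a 2.0-fold higher number from compound 1 to compound 4 (0.29 log units; within the scatter), so this ring offers no gain over methyl. Nothing measured here explains the gap between chloro and nitro. Still open, from the compounds shown here alone, is how an unsubstituted phenyl, or a phenyl carrying bromo or an amine, would compare with the 4-chlorophenyl of compound 2.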